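The source may report more compounds than this note shows. Statements on the series, on what has been measured and on what is new or still open speak of the compounds shown alone.

Measured in a functional assay on HepG2 cells (Homo sapiens) for antiproliferative activity, read by MTT assay, with a stated time of 48 h; a higher number here means a weaker inhibitor, a lower number a stronger inhibitor:
- compound 1 `N#CC1=C(N)Oc2c(c3nc4ccccc4nc3c3ccccc23)C12C(=O)N(Cc1cnnn1-c1ccc(S(N)(=O)=O)cc1)c1ccccc12`: 42200 nM
- compound 2 `Cc1cc(C)cc(-n2nncc2CN2C(=O)C3(C(C#N)=C(N)Oc4c3c3nc5ccccc5nc3c3ccccc43)c3ccccc32)c1`: a limit of this assay, > 50000 nM
- compound 3 `CCc1ccccc1-n1nncc1CN1C(=O)C2(C(C#N)=C(N)Oc3c(N)cc4nc5ccccc5nc4c32)c2ccccc21`: 17900 nM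

Compound 3 holds the lowest of the two numbers in this assay; compound 1 sits at a higher number, a gap beyond the usual scatter, and compound 2 contributes only a limit.

Compound 4 `CC(=O)Nc1ccc(-n2nncc2CN2C(=O)C3(C(C#N)=C(N)Oc4c(N)cc5nc6ccccc6nc5c43)c3ccccc32)cc1` is not yet measured. It differs from compound 3 in one place: 4-acetamidophenyl in place of 2-ethylphenyl on an aromatic nitrogen.

For the measured compounds named here, the one measured step that touches this position is an at least 1.1-fold higher number from compound 1 to compound 2 (0.07 log units; that floor lies within the scatter), where one aryl group on the triazole nitrogen replaced another. From the compounds shown here alone, that step reaches only (the limit of > 50000 nM in this assay, at which 1 of the 3 values shown sits), so its true size stays open, but nothing seen there points to a large change from swapping the aryl group at this nitrogen. A step of no more than the usual scatter is therefore expected in this assay, with the direction undecided.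

Compound 4 is expected at 24000 nM, within 9000 nM to 60000 nM. The expected step is a 1.3-fold higher number from compound 3 to compound 4 (0.13 log units; within the scatter).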

Compound 4, half-maximal inhibitory concentration: > 50000 nM
Compound 4 ended at the assay's limit (the forecaster's own chance of this, stated with the estimate: 25%); at least 2.0-fold (0.31 log units) between middle value and limit.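

In this assay, the aryl group on this aromatic nitrogen can matter: 4-acetamidophenyl in place of 2-ethylphenyl gives an at least 2.7-fold higher number from compound 3 to compound 4 (0.44 log units; beyond the scatter), whereas the earlier step at this position, an at least 1.1-fold higher number from compound 1 to compound 2 (0.07 log units; that floor lies within the scatter), had a floor that could not be told from scatter. Compound 4 gives only a limit of the assay, > 50000 nM. Only the floor of the new step is therefore known, and its true size stays open: the limit of > 50000 nM in this assay, at which 2 of the 4 values shown sit.

2-ethylphenyl and 4-acetamidophenyl differ both in the substituent and in its place on the phenyl ring, so the compounds shown cannot separate these two changes. They also leave open how a 4-aminophenyl group, a 4-carboxyphenyl group or a longer chain in place of the ethyl group would read in this assay.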